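The source may hold more compounds than are shown below. What is called first, only, known or untested is meant among the compounds shown, and "the series" means these compounds.

Compounds measured in an ADME assay on WI-38 cells (Homo sapiens) for cytotoxicity, read by MTT assay, with a stated time of 72 h; on this read-out higher numbers stand for weaker inhibition and lower numbers for stronger inhibition:
- compound 1 `O=C(CCc1cccc2c1B(O)OC2)Nc1ccc(Br)cc1`: 42000 nM
- compound 2 `CC(C)c1cccc(NC(=O)CCc2cccc3c2B(O)OC3)c1`: 22000 nM
- compound 3 `O=C(CCc1cccc2c1B(O)OC2)Nc1ccc2ccccc2c1`: > 100000 nM, which is a limit of the assay

Compound 2, at 22000 nM, lies within the scatter of compound 1, at 42000 nM. Compound 4 `COc1cc(OC)cc(-c2cccc(NC(=O)CCc3cccc4c3B(O)OC4)c2)c1` has 3,5-dimethoxyphenyl in place of isopropyl on an aromatic carbon of compound 2 (3,5-dimethoxyphenyl in place of isopropyl on an aromatic carbon). For the measured compounds named here, no pair of measured compounds differs in one place only, so the data give no direct guide to this change. No shift beyond the scatter is expected in this assay, and the estimated change is a 1.4-fold higher number from compound 2 to compound 4 (0.13 log units; within the scatter). For compound 4 the expected value is 30000 nM, with an estimated range of 9000 nM to 100000 nM.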

Compound 4, half-maximal inhibitory concentration: 1700 nM
The estimate for compound 4 lay 18-fold (1.25 log units) above the measured number, outside the stated range (below it).
By their numbers in this assay, from the lowest: compound 4; then compounds 2 and 1 (each within the scatter of the next). At a limit, above all of these: compound 3.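

In this assay, for the compounds shown here, the number at this position, on an aromatic carbon meta to a large group, responds to the substituent: 3,5-dimethoxyphenyl in place of isopropyl gives a 13-fold lower number from compound 2 to compound 4 (1.11 log units; beyond the scatter) as the first readable single-place step. This step lies beyond the scatter. Nothing shown bears on its cause.

Open, on these data alone, is whether the aromatic ring itself or its methoxy groups carry the step. An unsubstituted phenyl, an amine or a carboxylic acid at this position would help to separate these.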